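Benzoyl in place of butylcarbamoyl: notes toward compound 4

A few compounds are considered here, and "the series" means these few. Any claim that something is new, unique, unknown or untested is made for them only; others in the source may bear on it.

Three compounds of the series carry numbers in an assay on nucleic acid for inhibition of Nucleic Acid, read by fluorescence, tested at 100 uM; a higher number here means more inhibition at the concentration tested (going by the name of the read-out), a lower number less inhibition. Compound 1 `CCCCN(CCCC)Cc1cn(CC(O)COC(=O)c2ccccc2)nn1` gives 12%. Compound 2 `CN(Cc1cn(CC(O)COCc2ccccc2)nn1)CC1CCCCC1` gives 6%. Compound 3 `CCCCNC(=O)OCC(O)Cn1cc(CN(C)CC2CCCCC2)nn1` gives 12%. Among the measured compounds shown here, the one step between neighbours differing in a single place runs a number 6 percentage points higher from compound 2 to compound 3 (within the scatter), butylcarbamoyl in place of benzyl on an oxygen on a saturated carbon. Compound 3 thus stands level with compound 1 at the digits shown, and its gap to compound 2 lies within the scatter; all three numbers are small at the concentration tested, and none is set apart from the others.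

Compound 4 `CN(Cc1cn(CC(O)COC(=O)c2ccccc2)nn1)CC1CCCCC1` is not yet measured in this assay. It differs from compound 3 as follows: phenyl in place of butylamino on a carbonyl carbon. Cut one bond further out, the same difference reads butylcarbamoyl to benzoyl. Two things bear on it. The step of a number 6 percentage points higher from compound 2 to compound 3 (within the scatter) stays within the scatter. For the measured compounds named here, compound 1, which also carries benzoyloxy, gives 12%, but no single-place step between compound 1 and compound 4 is on record, so their values can only be set side by side. Nothing here has moved the number beyond the scatter, so the expected step of a number 2 percentage points lower from compound 3 to compound 4 (within the scatter) is none beyond the scatter. Compound 4 is expected to give 10%, within a range from 0% to 22%.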

Compound 4, a percentage reported as inhibition, at one concentration (the size of the read-out at that concentration, not a potency): 6%
Compound 4: the middle estimate sits 4 percentage points above what was measured; low and high end bracket the measured number.
By their numbers in this assay, from the lowest: compounds 2, 4, 1 and 3 (each within the scatter of the next).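

With the rest of the molecule held fixed, this assay now gives two further readings at the oxygen on a saturated carbon: phenyl in place of butylamino on the carbonyl carbon gives a number 6 percentage points lower from compound 3 to compound 4 (within the scatter) and benzoyl in place of benzyl gives no change at the digits printed from compound 2 to compound 4 (within the scatter) in the same series. Benzyl, benzoyl and butylcarbamoyl on this oxygen are therefore not told apart at the concentration tested, and the exchange of butylamino, with its hydrogen-bond donor, for phenyl, with its six-membered aromatic ring, does not take the number beyond the scatter. The other end of the molecule now has a reading as well, since (cyclohexylmethyl)(methyl)amino in place of dibutylamino on a saturated chain carbon bound to an aromatic carbon gives a number 6 percentage points lower from compound 1 to compound 4 (within the scatter) and so also leaves the number within the scatter.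

Whether any group on this oxygen can move the number beyond the scatter stays open, as a carboxylic acid, a primary amine or a longer chain carrying either has no value among the compounds shown. No supporting data are available to explain these numbers.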